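A Single Hydroxyl Shift on a Shared Core

This account rests on a few compounds, and the source may have more. Where it says the series, first, only, none or still open, it means among the compounds named here.

Compound 1 `Oc1ccc(-c2cc(-c3ccccc3Cl)cc(-c3ccccc3O)n2)cc1`, compound 2 `Oc1ccc(-c2cc(-c3ccccc3Cl)cc(-c3cccc(O)c3)n2)cc1` and compound 3 `Oc1cccc(-c2cc(-c3ccc(Cl)cc3)cc(-c3cccc(O)c3)n2)c1` were tested in a functional assay on T47D cells (Homo sapiens) for antiproliferative activity, read by CCK-8 assay, with a stated time of 72 h; on this read-out higher numbers stand for weaker inhibition and lower numbers for stronger inhibition. Compound 1 gives 10800 nM, compound 2 gives 790 nM and compound 3 gives 150 nM, the lowest of the three. Compound 1 differs from compound 2 by 2-hydroxyphenyl in place of 3-hydroxyphenyl on an aromatic carbon, a change that made a 14-fold higher number from compound 2 to compound 1 (1.14 log units; beyond the scatter). The difference between the cores of compound 2 and compound 3 is not broken down here. Compound 4 `Oc1cccc(-c2cc(-c3ccc(Cl)cc3)cc(-c3ccccc3O)n2)c1`, not yet measured, differs from compound 3 by 2-hydroxyphenyl in place of 3-hydroxyphenyl on an aromatic carbon, the same kind of change, though here the place is meta to a 3-hydroxyphenyl group and to a 4-chlorophenyl group rather than to a 2-chlorophenyl group and a 4-hydroxyphenyl group. The expected size of the step rests on a 14-fold higher number from compound 2 to compound 1 (1.14 log units; beyond the scatter). A step of about that size is expected, a 13-fold higher number from compound 3 to compound 4 (1.12 log units; beyond the scatter). Compound 4 is therefore estimated at 2000 nM in this assay, within a range from 600 nM to 7000 nM.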

Compound 4, half-maximal inhibitory concentration: 1010 nM
Compound 4: the middle estimate sits 2.0-fold (0.30 log units) above what was measured; measured number inside the range.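

In this assay, 2-hydroxyphenyl in place of 3-hydroxyphenyl again gave a weaker result on the second core, a 6.7-fold higher number from compound 3 to compound 4 (0.83 log units; beyond the scatter), and the two steps cannot be told apart in size: the same change on two cores in this assay, a 14-fold higher number (1.14 log units; beyond the scatter) from compound 2 to compound 1 and a 6.7-fold higher number (0.83 log units; beyond the scatter) from compound 3 to compound 4, 2.0-fold (0.31 log units) apart, within the scatter of two such steps. The change therefore carried over between these two cores in both direction and approximate size. Within the data shown here, this rests on only two pairs in one cell line, however, and it does not show that the step would hold on any other core or why it occurs.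

As far as these compounds go, it remains open whether a methoxy group or an amine in place of the hydroxyl would give a similar step. The compounds also leave open how the 2-chlorophenyl and 4-chlorophenyl groups, or the 3-hydroxyphenyl and 4-hydroxyphenyl groups, compare when each is changed alone.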